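The source may hold more compounds than are shown below. What is called first, only, known or untested is meant among the compounds shown, and "the series" means these compounds.

Compound 1 `COc1ccc(-c2c(C)nn(-c3nc(-c4ccc(Cl)c(Cl)c4)c(SC(C)C)s3)c2C(=O)O)cc1`: 2100 nM
Compound 2 `COc1cccc(-c2c(C)nn(-c3nc(-c4ccc(Cl)c(Cl)c4)c(SC(C)C)s3)c2C(=O)O)c1`: 14000 nM
Compound 3 `Cc1nn(-c2nc(-c3ccc(Cl)c(Cl)c3)c(SC(C)C)s2)c(C(=O)O)c1-c1ccccc1`: 3000 nM

All three compounds share one core and differ only in what sits on the phenyl ring. In a functional assay on BJAB cells (Homo sapiens) for antiproliferative activity, with a stated time of 4 days (a lower number here means that less compound is needed, a higher number that more compound is needed for the effect), compound 3 stands between the other two: compound 1 lies close by, with a 1.4-fold higher number from compound 1 to compound 3 (0.15 log units; within the scatter), so the two cannot be told apart, while compound 2 lies further off, with a 4.7-fold lower number from compound 2 to compound 3 (0.67 log units; beyond the scatter).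

Compound 4 `CC(=O)Nc1ccc(-c2c(C)nn(-c3nc(-c4ccc(Cl)c(Cl)c4)c(SC(C)C)s3)c2C(=O)O)cc1` has not yet been measured. The change from compound 3 is acetamido in place of hydrogen on an aromatic carbon. Going by the values given here, the steps that bear on this are the two that also alter the same phenyl ring. Adding a methoxy at the place where the acetamido now enters made little difference, as the step from compound 1 to compound 3 shows, whereas moving that methoxy to a different place on the ring cost a 4.7-fold lower number from compound 2 to compound 3 (0.67 log units; beyond the scatter). Among the compounds with values here, the acetamido is a larger group than methoxy and brings a hydrogen-bond donor as well as an acceptor, which no measured compound carries, so there is no direct precedent for it. On balance a small step, likely within the scatter, is expected, at a 1.2-fold lower number from compound 3 to compound 4 (0.08 log units; within the scatter). Compound 4 is therefore estimated at 2500 nM, with a range from 800 nM to 8000 nM.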

Compound 4, half-maximal effective concentration: 139000 nM
Compound 4: the middle estimate sits 56-fold (1.75 log units) below what was measured; measured number outside the range, above it.
By their numbers in this assay, from the lowest: compounds 1 and 3 (each within the scatter of the next); then compound 2; then compound 4.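

In this assay, the place para to a large group had looked undemanding, since compound 1 with methoxy there and compound 3 with only hydrogen could not be told apart. Acetamido changes that picture, with a 46-fold higher number from compound 3 to compound 4 (1.67 log units; beyond the scatter), and with a 66-fold higher number from compound 1 to compound 4 (1.82 log units; beyond the scatter) when it takes the place of methoxy, so this position accepts some groups but not all. The step also exceeds the cost of the methoxy shift seen earlier. Even compound 2, previously the highest number of the series, gives way to a 9.9-fold higher number from compound 2 to compound 4 (1.00 log units; beyond the scatter), which makes acetamido the most costly change on this ring among the four compounds. Nothing available here explains the jump.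

With only methoxy and acetamido at this place, the compounds shown cannot separate the effect of the group's size from that of its amide hydrogen or its carbonyl. An amine or a methyl ketone at the same place could help to divide these, and acetamido in the position held by the methoxy of compound 2 would show whether the loss follows the group wherever it sits on the ring.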